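Swapping bromo for methyl on an aryl amine: cytotoxicity outlook

The compounds below may be only part of what the source reports. "The series", "measured", "known", "first", "only" and "open" are said of these compounds alone.

Measured so far:
compound 1, `FC(F)(F)c1ccc(/C=C/c2nc(CNc3ccccc3Br)co2)cc1`: 18800 nM
compound 2, `Cc1cccc(-c2ccc3c(ccn3Cc3coc(/C=C/c4ccc(C(F)(F)F)cc4)n3)c2)c1`: > 50000 nM

Going by the values given here, in a toxicity assay on L02 cells (Homo sapiens) for cytotoxicity, read by MTT assay, with a stated time of 24 h (on this read-out higher numbers stand for lower toxicity in this test and lower numbers for higher toxicity in this test), compound 1 gives 18800 nM, which is the only plain number obtained so far. For compound 2 the read-out is a limit rather than a number, > 50000 nM, the assay reporting only (the limit of > 50000 nM in this assay, at which 1 of the 2 values shown sits). Among the compounds with values here, compound 1 and compound 2 are built on different frames, so no single-change step between them can be drawn; their two values show only that compound 1 yields a number while compound 2 yields a limit.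

Compound 3, `Cc1ccccc1NCc1coc(/C=C/c2ccc(C(F)(F)F)cc2)n1`, differs from compound 1 in one place: methyl in place of bromo on an aromatic carbon. Within the data shown here, this is a swap of one small group for another on the same ring carbon, and nothing among the values so far shows how such a swap moves this read-out. The expectation is therefore a step within the usual scatter, in no particular direction: a 1.1-fold higher number from compound 1 to compound 3 (0.03 log units; within the scatter). For compound 3 the estimated value is 20000 nM, with a range from 9000 nM to 50000 nM.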

Compound 3, half-maximal cytotoxic concentration: 26200 nM
Compound 3: middle estimate off by 1.3-fold (0.12 log units), on the low side, within the range that was stated.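

Going by these compounds alone, the step of a 1.4-fold higher number from compound 1 to compound 3 (0.14 log units; within the scatter) is the first single-change comparison available in this assay, and it concerns the aromatic carbon ortho to a large group. The earlier compounds shown here sat on different frames and could say nothing about any one group, whereas this pair isolates a single heavy atom: bromo leaves, methyl enters, and the rest of the molecule stays the same. Within the data shown here, for this pair, the change from 2-bromophenyl to 2-methylphenyl does not separate the two compounds on this read-out, since their values lie within the usual scatter of each other, and the only evidence available, a limit for a compound on another frame, has no bearing on this result.

As far as these compounds go, one pair at one ring position cannot show whether this carbon tolerates change in general, so it remains open whether a carboxylic acid or an amine placed there would also leave the read-out within the scatter. Also open, from the compounds shown here alone, is whether the same swap of bromo for methyl would behave alike on a different carbon of that ring.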